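This account rests on a few compounds, and the source may have more. Where it says the series, first, only, none or still open, it means among the compounds named here.

Compound 1 `Cc1cc(NC(=O)Nc2ccc(C)c(Cl)c2)c2ccccc2n1` gives, in an ADME assay on HEK293 cells (Homo sapiens) for cytotoxicity, with a stated time of 72 h (a lower number here means that less compound is needed, a higher number that more compound is needed for the effect), a limit of > 25000 nM.
Compound 2 `Cc1ccc(NC(=O)Nc2cc(C)nc3ccccc23)cc1` gives in this assay a limit of > 25000 nM.
Compound 3 `Cc1cc(NC(=O)Nc2ccc(F)cc2F)c2ccccc2n1` gives in this assay 10000 nM.

Compound 2 therefore stands at a limit in this assay, not at a number. Going by the values given here, the one measured step, a step that the two limits leave unreadable from compound 1 to compound 2, cannot be read because the limit of > 25000 nM in this assay, at which 2 of the 3 values shown sit, is where both of its ends sit, so no step size is available for any change at this part of the molecule.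

Compound 4 `Cc1cc(NC(=O)Nc2ccc(C(N)=O)cc2)c2ccccc2n1` differs from compound 2 by carbamoyl in place of methyl on an aromatic carbon. Among the compounds with values here, no measured step bears on a carbamoyl, so no shift beyond the scatter is expected, and the limit seems the likeliest outcome. Compound 4 is expected to give about 25000 nM, between 10000 nM and 60000 nM. The expected step is a number no higher from compound 2 to compound 4 (the limit leaves the size open).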

Compound 4, half-maximal effective concentration: > 25000 nM
Compound 4: no number, only a limit (the forecaster's own chance of this, stated with the estimate: 70%); the middle value sits exactly at the limit.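

Compound 2 and compound 4 both stand at a limit, so the step between them cannot be read: the limit of > 25000 nM in this assay, at which 3 of the 4 values shown sit. The compounds shown leave open whether carbamoyl in place of methyl on an aromatic carbon changes the half-maximal effective concentration in this assay at all.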